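Swapping the acid for a dimethylamide on the shared core

A few compounds are considered here, and "the series" means these few. Any claim that something is new, unique, unknown or untested is made for them only; others in the source may bear on it.

In an assay on cells for inhibition of Rho-associated protein kinase 2 (Homo sapiens) (on this read-out lower numbers stand for stronger inhibition and higher numbers for weaker inhibition), compound 1 `COc1cc(NC(=O)C2COc3ccccc3C2)ccc1-c1cn[nH]c1` gives 7 nM. Compound 2 `Cc1ccc2c(c1)CC(C(=O)Nc1ccc(-c3cn[nH]c3)cc1)CO2` gives 4000 nM, and compound 3 `O=C(O)c1ccc2c(c1)CC(C(=O)Nc1ccc(-c3cn[nH]c3)cc1)CO2` gives 751 nM, the second highest of the three numbers. For the measured compounds named here, the one measured step, a 5.3-fold lower number from compound 2 to compound 3 (0.73 log units; beyond the scatter), is a modest gain. Compound 4 `CN(C)C(=O)c1ccc2c(c1)CC(C(=O)Nc1ccc(-c3cn[nH]c3)cc1)CO2` differs from compound 3 by dimethylamino in place of hydroxy on a carbonyl carbon. Going by the values given here, no measured step shows what this change does; the step from compound 2 to compound 3 only tells that the acid helped relative to methyl, and that gain may not carry over once the acid is gone. The expected change is therefore a small loss or no change beyond the scatter, a 2.0-fold higher number from compound 3 to compound 4 (0.30 log units; within the scatter), with compound 4 estimated at 1500 nM in this assay, between 400 nM and 6000 nM.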

Compound 4, half-maximal inhibitory concentration: 500 nM
Beside the measured number, compound 4's estimate is 3.0-fold (0.48 log units) above it, and the stated range covers the measured number.
By their numbers in this assay, from the lowest: compound 1; then compounds 4 and 3 (each within the scatter of the next); then compound 2.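

On this carbonyl carbon, hydroxy can give way to dimethylamino with no change that stands out in this assay (a 1.5-fold lower number from compound 3 to compound 4 (0.18 log units; within the scatter)), so the hydrogen-bond donor of the acid is not needed to hold this level. The gain over methyl also remains without the acid (an 8.0-fold lower number from compound 2 to compound 4 (0.90 log units; beyond the scatter)). Nothing available explains either step. As far as these compounds go, whether a primary amide or an aminomethyl group at this place would give a lower number stays open. So does whether a longer chain on the amide nitrogen would be tolerated.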